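Swapping the anilide for a fluorobenzyl amide

This account rests on a few compounds, and the source may have more. Where it says the series, first, only, none or still open, it means among the compounds named here.

Measured compounds:
- Compound 1, `COc1ccc2c(=O)c(/C=C/C(=O)Nc3cc(C)ccc3C)coc2c1`: 11100 nM
- Compound 2, `COc1ccc2c(=O)c(/C=C/C(=O)Nc3ccccc3)coc2c1`: 9050 nM
- Compound 3, `COc1ccc2c(=O)c(/C=C/C(=O)Nc3ccc(Cl)cc3)coc2c1`: 37100 nM

All three share one core and differ only in the group on the amide nitrogen. In a functional assay on Huh-7 cells (Homo sapiens) for inhibition, read by MTT assay, with a stated time of 48 h (on this read-out higher numbers stand for weaker inhibition and lower numbers for stronger inhibition), compound 3 gives the highest number of the three: the step of a 3.3-fold higher number from compound 1 to compound 3 (0.52 log units; beyond the scatter) and the step of a 4.1-fold higher number from compound 2 to compound 3 (0.61 log units; beyond the scatter) both lie beyond the scatter, while a 1.2-fold lower number from compound 1 to compound 2 (0.09 log units; within the scatter) does not.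

Compound 4, `COc1ccc2c(=O)c(/C=C/C(=O)NCc3ccc(F)cc3)coc2c1`, has not yet been measured. It differs from compound 3 in one place: 4-fluorobenzyl in place of 4-chlorophenyl on an amide-type nitrogen. Within the data shown here, no measured pair shows a benzyl in place of a phenyl, so that part of the change is uncharted. The step of a 4.1-fold higher number from compound 2 to compound 3 (0.61 log units; beyond the scatter) is the one that bears on it: removing the chloro, even with a fluoro and an extra carbon entering, is expected to undo at least part of that rise. A modest fall in this assay, a 2.5-fold lower number from compound 3 to compound 4 (0.39 log units; beyond the scatter), is therefore expected, though with wide uncertainty. Compound 4 is estimated at 15000 nM, in the range 4000 nM to 60000 nM.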

Compound 4, half-maximal inhibitory concentration: 21000 nM
The estimate for compound 4 lay 1.4-fold (0.15 log units) below the measured number, and the stated range covers the measured number.
By their numbers in this assay, from the lowest: compounds 2, 1, 4 and 3 (each within the scatter of the next, the first and the last beyond it).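

In this assay, among these compounds, compound 4 brings the first benzyl-type group to the amide nitrogen, and a 1.8-fold lower number from compound 3 to compound 4 (0.25 log units; within the scatter) shows that exchanging 4-chlorophenyl for 4-fluorobenzyl does not move the number clearly beyond ordinary assay noise. The new group also stays within the scatter of the 2,5-dimethylphenyl group, with a 1.9-fold higher number from compound 1 to compound 4 (0.28 log units; within the scatter), but it separates clearly from the plain phenyl group, with a 2.3-fold higher number from compound 2 to compound 4 (0.37 log units; beyond the scatter), so among these comparisons only the phenyl amide stands apart from it. No measurement here gives a reason for these differences.

Compound 4 changes two things at once, adding a carbon between the nitrogen and the ring and carrying fluoro where compound 3 carries chloro, so a plain benzyl or a 4-chlorobenzyl group on the same nitrogen would be needed to separate those two contributions. The compounds shown also leave open how this position would respond to a longer chain, such as 2-phenylethyl, or to a ring bearing an amine or a carboxylic acid.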